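Iodo in Place of Bromo: Expecting Another Limit

The source may report more compounds than this note shows. Statements on the series, on what has been measured and on what is new or still open speak of the compounds shown alone.

Compound 3 `[N-]=[N+]=N[C@@H]1C(n2cc(Br)c(=O)[nH]c2=O)[Se][C@H](CO)[C@H]1O` belongs to a set of three compounds sharing one core and differing only in the group on one aromatic carbon. In a functional assay on SNU-638 cells (Homo sapiens) for cytotoxicity, read by sulforhodamine B assay (on this read-out lower numbers stand for stronger inhibition and higher numbers for weaker inhibition), compound 1 `Cc1cn(C2[Se][C@H](CO)[C@@H](O)[C@@H]2N=[N+]=[N-])c(=O)[nH]c1=O` reaches only the limit of the assay, > 100000 nM. Compound 2 `[N-]=[N+]=N[C@@H]1C(n2cc(Cl)c(=O)[nH]c2=O)[Se][C@H](CO)[C@H]1O` likewise gives a limit, > 100000 nM. Compound 3 too gives a limit, > 100000 nM. The steps a step that the two limits leave unreadable from compound 1 to compound 2, a step that the two limits leave unreadable from compound 1 to compound 3 and a step that the two limits leave unreadable from compound 2 to compound 3 cannot be read, since (the limit of > 100000 nM in this assay, at which 3 of the 3 values shown sit). Compound 4 `[N-]=[N+]=N[C@@H]1C(n2cc(I)c(=O)[nH]c2=O)[Se][C@H](CO)[C@H]1O` is not yet measured; it differs from compound 3 by iodo in place of bromo on an aromatic carbon. For the measured compounds named here, no measured step gives a readable size for such a change, so compound 4 is expected to stay at the limit as well, estimated at 100000 nM (between 50000 nM and 200000 nM), a step of a number no higher from compound 3 to compound 4 (the limit leaves the size open).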

Compound 4, half-maximal inhibitory concentration: > 100000 nM
Compound 4 ended at the assay's limit; the forecaster's own chance of this, stated with the estimate: 85%; the middle value sits exactly at the limit.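

For the compounds shown here, no step from compound 4 to compound 1, compound 2 or compound 3 can be read, because all four stop at one limit: the limit of > 100000 nM in this assay, at which 4 of the 4 values shown sit.
The compounds shown leave open how strongly any of them acts on these cells, and whether the group on that aromatic carbon matters at all.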